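The source may hold more compounds than are shown below. What is called first, only, known or untested is meant among the compounds shown, and "the series" means these compounds.

Compound 1, with structure `CCOC(=O)c1cccc(-c2ccc(OCC)cc2)c1`, is one of three closely related compounds tested in an assay on COS-7 cells for inhibition of patatin-like phospholipase domain-containing protein 2 (Mus musculus); on this read-out lower numbers stand for stronger inhibition and higher numbers for weaker inhibition. Compound 1 gives 50000 nM, the lowest of the three numbers. Compound 2, structure `CCOC(=O)c1cccc(-c2ccc([N+](=O)[O-])cc2)c1`, gives 95000 nM, and the step of a 1.9-fold higher number from compound 1 to compound 2 (0.28 log units; within the scatter) lies within the scatter, so the two numbers cannot be told apart. Compound 3, structure `CCOC(=O)c1cccc(-c2ccc(OCC)c(N)c2)c1`, gives 140000 nM, and the step of a 2.8-fold higher number from compound 1 to compound 3 (0.45 log units; beyond the scatter) is modest but beyond the scatter.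

Compound 4, structure `CCOc1ccc(-c2cccc(C)c2)cc1`, differs from compound 1 by methyl in place of ethoxycarbonyl on an aromatic carbon. Neither measured step touches this part of the molecule: both changed the ring that carries the ethoxy group, leaving the ethoxycarbonyl untouched. There is thus no direct evidence for what happens when the ethoxycarbonyl is exchanged for a methyl. What the three numbers do show is that every change made so far has given a number at or above that of compound 1, and none has given a lower one. On that basis compound 4 is expected to give a number that is at best similar to compound 1 and more likely somewhat higher, a step of a 2.0-fold higher number from compound 1 to compound 4 (0.30 log units; within the scatter) in this assay. The estimate for compound 4 is 100000 nM, with a range from 35000 nM to 300000 nM.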

Compound 4, half-maximal inhibitory concentration: 70000 nM
The estimate for compound 4 lay 1.4-fold (0.15 log units) above the measured number; the measured number falls inside the stated range.
By their numbers in this assay, from the lowest: compounds 1, 4, 2 and 3 (each within the scatter of the next, the first and the last beyond it).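

Exchanging the ethoxycarbonyl for methyl gives a 1.4-fold higher number from compound 1 to compound 4 (0.15 log units; within the scatter), so in this assay the numbers for these two compounds cannot be told apart. This is the only step shown at this position, as the other two steps changed the ring that carries the ethoxy group, and it shows that a group of 5 heavy atoms with 2 hydrogen-bond acceptors can give way to a single-carbon methyl with no hydrogen-bond acceptors without a shift beyond the scatter. The ethoxycarbonyl, including its double bond outside the aromatic rings, is therefore not required for a number in this range, although no measurement on hand explains this result.

Methyl and ethoxycarbonyl are the only two groups shown at this position, so it remains open whether a carboxylic acid, an amine or a longer chain there would give a clearly lower or higher number. On these data alone, it is also open whether methyl would behave the same way in a compound carrying nitro in place of ethoxy, or amino on the ethoxy-bearing ring.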